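A few compounds are considered here, and "the series" means these few. Any claim that something is new, unique, unknown or untested is made for them only; others in the source may bear on it.

Compound 1 `CN(C)c1ccc(C(=O)N[C@@H](CCCCCC(=O)NO)C(=O)NCc2ccccc2)cc1` and compound 2 `CN(C)c1ccc(C(=O)N[C@H](CCCCCC(=O)NO)C(=O)NCc2ccccc2)cc1` share one skeleton and differ only in the configuration drawn at a saturated chain carbon. In a functional assay on MM96L cells (Homo sapiens) for antiproliferative activity (on this read-out lower numbers stand for stronger inhibition and higher numbers for weaker inhibition), compound 1 gives 1600 nM, and compound 2 gives 160 nM. Among the measured compounds shown here, compound 1 thus stands with the highest number of the two measured compounds; the step of a 10-fold lower number from compound 1 to compound 2 (1.00 log units; beyond the scatter) is the only measured step in the set, and its cause is traced to the fact that compounds 1 and 2 differ only in the configuration as drawn.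

Compound 3 `O=C(/C=C/c1ccccc1)N[C@@H](CCCCCC(=O)NO)C(=O)NCc1ccccc1` keeps the configuration of compound 1 and exchanges the group on the carbonyl carbon: 2-phenylethenyl in place of 4-(dimethylamino)phenyl on a carbonyl carbon. For the measured compounds named here, no measured step bears on such an exchange; the single step from compound 1 to compound 2 concerns configuration alone, and nothing in the data shows how a replacement on the carbonyl carbon moves the number in this assay. The expectation for compound 3 therefore rests on compound 1 alone, anchored to 1600 nM. The step of no change at the digits printed from compound 1 to compound 3 (within the scatter) is expected to remain within the scatter. Compound 3 is estimated at 1600 nM, with a range of 400 nM to 6400 nM, the width reflecting the absence of any measured change of this kind.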

Compound 3, half-maximal inhibitory concentration: 460 nM
The estimate for compound 3 lay 3.5-fold (0.54 log units) above the measured number; measured number inside the range.
By their numbers in this assay, from the lowest: compound 2; then compound 3; then compound 1.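

The carbonyl-carbon position, which the earlier pair left untouched, proves able to move the number: in this assay the exchange of 4-(dimethylamino)phenyl for 2-phenylethenyl gives a 3.5-fold lower number from compound 1 to compound 3 (0.54 log units; beyond the scatter) with the configuration held as in compound 1. The exchange keeps one six-membered aromatic ring of carbon only, while it adds a double bond outside aromatic rings and removes the nitrogen and its hydrogen-bond acceptor, so a single step cannot show which of these differences accounts for the change. Nothing measured on these compounds speaks to the reason for this step.

The compounds shown leave open whether the same exchange gives a step of similar size in the configuration of compound 2, since 2-phenylethenyl appears here only in the configuration of compound 1. Also open, going by these compounds, is how far the double bond itself matters, which a saturated 2-phenylethyl group or a plain phenyl group on the same carbonyl carbon would begin to separate from the effect of losing the dimethylamino group.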